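The source may report more compounds than this note shows. Statements on the series, on what has been measured and on what is new or still open speak of the compounds shown alone.

Measured so far:
- Compound 1 `CN(C)Cc1csc(NC(=O)c2cc(C(C)(C)C)nn2Cc2ccccc2)n1`: > 100 ug/mL (a limit, not a number)
- Compound 2 `CC(C)(C)c1cc(C(=O)Nc2ccccn2)n(Cc2ccccc2)n1`: 25 ug/mL

Going by the values given here, in a physicochemical assay for solubility, read by nephelometry, measured as kinetic solubility, at pH 2.0 (a higher number here means a more soluble compound, a lower number a less soluble compound), compound 2 gives 25 ug/mL, the only true number so far. The next compound is compound 3 `CC(C)(C)c1cc(C(=O)Nc2ccccc2)n(Cc2ccccc2)n1`, with phenyl in place of pyridin-2-yl on an amide-type nitrogen. Among the compounds with values here, the one measured step at this amide-type nitrogen is an at least 4.0-fold lower number from compound 1 to compound 2 (0.60 log units; beyond the scatter). That step involved a different group, so it is only a loose guide. A smaller step in the same direction is expected, a 2.5-fold lower number from compound 2 to compound 3 (0.40 log units; beyond the scatter). Compound 3 is estimated at 10 ug/mL, with an expected range of 3 ug/mL to 25 ug/mL.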

Compound 3, solubility: 1.6 ug/mL
The estimate for compound 3 lay 6.3-fold (0.80 log units) above the measured number; measured number outside the range, below it.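

In this assay, exchanging one ring nitrogen for carbon at the amide-type nitrogen goes with a 16-fold lower number from compound 2 to compound 3 (1.19 log units; beyond the scatter). The widest span at this position is an at least 62-fold lower number from compound 1 to compound 3 (1.79 log units; beyond the scatter), and that figure is only a bound. Compound 1 gives > 100 ug/mL, a limit and not a number, so the true size of that span stays unknown: the limit of > 100 ug/mL in this assay, at which 1 of the 3 values shown sits.

Still open, going by these compounds, is how a phenyl carrying an amine or a carboxylic acid would read in this assay. Also open, on these data alone, is how much of the gap to compound 1 belongs to its dimethylamino group rather than to its thiazole ring.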